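The compounds below may be only part of what the source reports. "The series", "measured", "known", "first", "only" and "open" are said of these compounds alone.

Compound 1 `C=C1C(=O)[C@]23C[C@@]1(O)CC[C@H]2c1ccc(OS(=O)(=O)c2ccc(C)cc2)c(C)c1[C@@H]3Cn1cc(-c2ccc(Br)cc2)nn1` carries a (4-methylphenyl)sulfonyl group on an oxygen on an aromatic ring of the shared core, together with a 4-bromophenyl group. Among the measured compounds shown here, in a functional assay on SW480 cells (Homo sapiens) for cytotoxicity, read by MTT assay, with a stated time of 4 days (a higher number here means a weaker inhibitor, a lower number a stronger inhibitor), compound 1 gives 1590 nM, the highest of the two numbers known here. Compound 2 `C=C1C(=O)[C@]23C[C@@]1(O)CC[C@H]2c1ccc(O)c(C)c1[C@@H]3Cn1cc(-c2ccc(Br)cc2)nn1`, with hydrogen in place of that sulfonyl group, gives 310 nM, so that a 5.1-fold lower number from compound 1 to compound 2 (0.71 log units; beyond the scatter). Compound 3 `Cc1ccc(S(=O)(=O)Oc2ccc3c(c2C)[C@H](Cn2cc(-c4ccc(C(F)(F)F)cc4)nn2)[C@@]24CC(=O)[C@@](C)(CC[C@@H]32)C4)cc1` reached only a limit of this assay, > 20000 nM. Compound 4 `C=C1C(=O)[C@]23C[C@@]1(O)CC[C@H]2c1ccc(OS(=O)(=O)c2ccc(C)cc2)c(C)c1[C@@H]3Cn1cc(-c2ccc(OC)cc2)nn1` keeps the sulfonyl group of compound 1 and differs from it only by methoxy in place of bromo on an aromatic carbon. For the measured compounds named here, no measured step alters this part of the molecule, so nothing here sets a direction. The expected change is a 1.0-fold higher number from compound 1 to compound 4 (0.00 log units; within the scatter), within the scatter. Compound 4 is therefore estimated at 1600 nM, between 600 nM and 4500 nM.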

Compound 4, half-maximal inhibitory concentration: 1640 nM
For compound 4 the middle estimate is 1.0-fold (0.01 log units) below the measured one; measured number inside the range.
By their numbers in this assay, from the lowest: compound 2; then compounds 1 and 4 (each within the scatter of the next). At a limit, above all of these: compound 3.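

Among the compounds shown here, the earlier step changed only the sulfonyl group, so this is the first measured look at the para substituent on the phenyl ring. In this assay, methoxy in place of bromo gives a 1.0-fold higher number from compound 1 to compound 4 (0.01 log units; within the scatter), so with the sulfonyl group kept, 4-bromophenyl and 4-methoxyphenyl cannot be told apart at this position. Nothing measured here bears on why the two read alike. As far as these compounds go, whether the same holds on compound 2, which lacks the sulfonyl group, stays open. So does what an amine or a carboxylic acid would do at this position.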